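The compounds below may be only part of what the source reports. "The series", "measured", "known", "first", "only" and "open" are said of these compounds alone.

Working notes on the series.

The shared core carries a conjugated enone whose carbonyl carbon bears a varying aromatic group. Compound 1 `COc1ccc(-c2cc3ccccc3nc2/C=C/C(=O)c2ccccc2)cc1`, with phenyl on that carbon, gives 1410 nM in a functional assay on NCI-H1299 cells (Homo sapiens) for antiproliferative activity, read by XTT assay, with a stated time of 72 h; on this read-out higher numbers stand for weaker inhibition and lower numbers for stronger inhibition. Going by the values given here, compound 2 `COc1ccc(-c2cc3ccccc3nc2/C=C/C(=O)c2ccco2)cc1`, with furan-2-yl there, gives 730 nM in this assay; the only step in hand, a 1.9-fold lower number from compound 1 to compound 2 (0.29 log units; within the scatter), does not separate the two compounds beyond the scatter.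

Compound 3 `COc1ccc(-c2cc3ccccc3nc2/C=C/C(=O)c2ccsc2)cc1` is not yet measured. Its difference from compound 2 is thiophen-3-yl in place of furan-2-yl on a carbonyl carbon. Among the compounds with values here, the one measured step that bears on this position, a 1.9-fold lower number from compound 1 to compound 2 (0.29 log units; within the scatter), exchanged one aromatic group for another at the same carbonyl carbon and stayed within the scatter. The expected step in this assay from compound 2 to compound 3 is therefore small, with no clear direction, about a 1.1-fold higher number from compound 2 to compound 3 (0.04 log units; within the scatter). On that basis compound 3 is estimated at 800 nM in this assay, with a range from 350 nM to 1800 nM.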

Compound 3, half-maximal inhibitory concentration: 1220 nM
Compound 3: middle estimate off by 1.5-fold (0.18 log units), on the low side; measured number inside the range.
By their numbers in this assay, from the lowest: compounds 2, 3 and 1 (each within the scatter of the next).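

Thiophen-3-yl brings a sulfur-containing five-membered aromatic ring onto the carbonyl carbon, and in this assay both of its steps stay within the scatter (a 1.7-fold higher number from compound 2 to compound 3 (0.22 log units; within the scatter); a 1.2-fold lower number from compound 1 to compound 3 (0.06 log units; within the scatter)). Going by these compounds alone, the single earlier step could only separate phenyl from furan-2-yl; with this third group, all three aromatic groups sit within the scatter of one another, so exchange among them at this position has no resolved effect on the read-out. No measurement in hand offers an explanation for these numbers.

On these data alone, whether a group of another kind on this carbonyl carbon, such as a piperidine ring, a phenyl ring carrying an amine or a carboxylic acid, or a longer alkyl chain, would move the number beyond the scatter remains open. The compounds shown also leave open how the rest of the shared core contributes, since they vary in this one place only.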